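Methyl Ester Against Free Acid in a Cytotoxicity Read-out

The source may hold more compounds than are shown below. What is called first, only, known or untested is meant among the compounds shown, and "the series" means these compounds.

Compound 3 `O=C(O)c1ccc(-c2noc(CCl)n2)cc1` and compound 1 `COC(=O)c1ccc(-c2noc(CCl)n2)cc1` share one core. In an ADME assay on MT2 cells (Homo sapiens) for cytotoxicity, read by XTT assay, with a stated time of 4 days (on this read-out lower numbers stand for higher toxicity in this test and higher numbers for lower toxicity in this test), compound 3 gives 64000 nM, while compound 1 gives 14200 nM. The change between them, (methyl in place of hydrogen on an oxygen next to a carbonyl group), brings a 4.5-fold lower number from compound 3 to compound 1 (0.65 log units; beyond the scatter). Compound 2 `O=C(O)c1ccc(N2C(=O)C=CC2=O)cc1O` is built on another core; the difference between the two cores is not broken down here. In this assay compound 2 reaches only a limit, > 400000 nM. Among the three values, one sits at the limit of > 400000 nM in this assay, at which 1 of the 3 values shown sits. Compound 4 `COC(=O)c1ccc(N2C(=O)C=CC2=O)cc1O` differs from compound 2 by the same change, (methyl in place of hydrogen on an oxygen next to a carbonyl group), at the same place. Since compound 2 stands only at a limit, the starting point is uncertain, and the estimate for compound 4 is 150000 nM, between 40000 nM and 600000 nM. The expected step is an at least 2.6-fold lower number from compound 2 to compound 4 (0.42 log units; beyond the scatter), resting on the earlier step of a 4.5-fold lower number from compound 3 to compound 1 (0.65 log units; beyond the scatter).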

Compound 4, half-maximal cytotoxic concentration: 66200 nM
For compound 4 the middle estimate is 2.3-fold (0.36 log units) above the measured one; the measured number falls inside the stated range.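

In this assay, methyl in place of hydrogen on an oxygen next to a carbonyl group carries its direction over to the second core, bringing an at least 6.0-fold lower number from compound 2 to compound 4 (0.78 log units; beyond the scatter). Whether the size of the step carries over as well stays unsettled, and two cores give no rule for any other core in the series: the same change on two cores in this assay, a 4.5-fold lower number (0.65 log units; beyond the scatter) from compound 3 to compound 1 and an at least 6.0-fold lower number (0.78 log units; beyond the scatter) from compound 2 to compound 4; the limit leaves it open whether they differ

The value of compound 2 is a limit and not a number: the limit of > 400000 nM in this assay, at which 1 of the 4 values shown sits.

The compounds shown leave open whether a longer chain on the same oxygen, such as an ethyl ester, would lower the number further. They also leave open how an amide at that place would read.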